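Methoxycinnamate esters of a trimethylpyrazinyl carbinol

The source may hold more compounds than are shown below. What is called first, only, known or untested is meant among the compounds shown, and "the series" means these compounds.

Measured so far:
Compound 1 `COc1ccccc1/C=C/C(=O)OCc1nc(C)c(C)nc1C`: < 24000 nM
Compound 2 `COc1cccc(/C=C/C(=O)OCc2nc(C)c(C)nc2C)c1`: < 24000 nM

Read-out is a functional assay on PC-12 cells (Rattus norvegicus); on this read-out higher numbers stand for an effect only at larger amounts of compound and lower numbers for an effect already at smaller amounts. For the measured compounds named here, only two compounds have been measured, and neither gives a number. For compound 2 the value < 24000 nM is a limit of the assay, not a measured concentration. The same holds for compound 1, so every value shown is a limit: the limit of < 24000 nM in this assay, at which 2 of the 2 values shown sit. Compound 2 thus stands at the limit together with compound 1, and no ordering between the two can be drawn. Going by the values given here, no step between measured compounds exists for this series.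

The next compound, compound 3 `COc1ccc(OC)c(/C=C/C(=O)OCc2nc(C)c(C)nc2C)c1`, keeps the core of compound 2 and adds a methoxy group: methoxy in place of hydrogen on an aromatic carbon. Without any measured step, no direction is expected from this change; the step that the limit leaves unreadable from compound 2 to compound 3 is estimated as none beyond the scatter. Compound 3 is expected near 10000 nM, in the range 2000 nM to 24000 nM, most likely again reported only as a limit.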

Compound 3, half-maximal effective concentration: < 24000 nM
Compound 3 ended at the assay's limit; the forecaster's own chance of this, stated with the estimate: 60%; the middle value is on the limit's open side.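

No step can be read from compound 1 or compound 2 to compound 3, since all three values are limits and not numbers: the limit of < 24000 nM in this assay, at which 3 of the 3 values shown sit.

Still open, on these data alone, is whether the methoxy group entering in compound 3 shifts the read-out at all, and in which direction.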